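Trifluoromethyl step from compound 2 in the amide series

The source may hold more compounds than are shown below. What is called first, only, known or untested is meant among the compounds shown, and "the series" means these compounds.

Within the data shown here, compound 2 `O=C(NCc1ccc(S(=O)(=O)c2ccccc2)cc1)c1ccc2nccn2c1` gives 18 nM in an assay for inhibition of Nicotinamide phosphoribosyltransferase (Homo sapiens), read by mass spectrometry, with stated times of 15 min and 30 min (on this read-out higher numbers stand for weaker inhibition and lower numbers for stronger inhibition), the lowest of the three numbers so far. Compound 1 `O=C(NCc1ccc(S(=O)(=O)c2ccccc2)cc1)c1cn2ccnc2cn1` gives 150 nM, and compound 3 `O=C(NCc1ccc(S(=O)(=O)c2ccccc2)cc1)c1nc2ccncc2s1` gives 210 nM; the measured steps are an 8.3-fold lower number from compound 1 to compound 2 (0.92 log units; beyond the scatter), a 1.4-fold higher number from compound 1 to compound 3 (0.15 log units; within the scatter) and a 12-fold higher number from compound 2 to compound 3 (1.07 log units; beyond the scatter), all of them swaps of the group on the carbonyl carbon. Compound 4 `O=C(NCc1ccc(S(=O)(=O)c2cccc(C(F)(F)F)c2)cc1)c1ccc2nccn2c1` keeps the group of compound 2 and differs only by trifluoromethyl in place of hydrogen on an aromatic carbon, phenyl to 3-(trifluoromethyl)phenyl. Among the measured compounds shown here, no measured step touches this part of the molecule, so nothing among the three compounds speaks for or against the change, and a step within the scatter is expected, no change at the digits printed from compound 2 to compound 4 (within the scatter). Compound 4 is therefore estimated at 18 nM, ranging from 6 nM to 55 nM.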

Compound 4, half-maximal inhibitory concentration: 8 nM
For compound 4 the middle estimate is 2.3-fold (0.35 log units) above the measured one; low and high end bracket the measured number.
By their numbers in this assay, from the lowest: compound 4; then compound 2; then compounds 1 and 3 (each within the scatter of the next).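

Among these compounds, this is the only measured step away from the group on the carbonyl carbon: in this assay, trifluoromethyl in place of hydrogen on the phenyl ring gives a 2.3-fold lower number from compound 2 to compound 4 (0.35 log units; beyond the scatter) and so the ring carries this substituent with no loss of inhibition. The step is modest but beyond the scatter. Nothing available accounts for the gain.

From the compounds shown here alone, whether the gain is specific to trifluoromethyl stays open, as a chlorine atom, a methyl or a methoxy group in the same place would test this. Also open, going by these compounds, is whether the same change carries over to the cores of compound 1 and compound 3.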